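This account rests on a few compounds, and the source may have more. Where it says the series, first, only, none or still open, it means among the compounds named here.

Values in a functional assay on A-375 cells (Homo sapiens) for cytotoxicity, read by MTT assay; a higher number here means a weaker inhibitor, a lower number a stronger inhibitor:

- Compound 1 `COc1ccc(/C=C/C(=O)c2ccc(OC)c3c2OC(C)(C)C=C3)cc1OCCCN(C)C`: 4100 nM
- Compound 2 `COc1ccc(/C=C/C(=O)c2ccc(OC)c3c2OC(C)(C)C=C3)cc1OC(=O)C1CC1`: 380 nM
- Compound 3 `COc1ccc(/C=C/C(=O)c2ccc(OC)c3c2OC(C)(C)C=C3)cc1OS(=O)(=O)Cc1ccccc1`: > 10000 nM, a limit of the assay and not a number
- Compound 4 `COc1ccc(/C=C/C(=O)c2ccc(OC)c3c2OC(C)(C)C=C3)cc1OS(=O)(=O)c1ccc(C)cc1`: not yet measured

Compound 3 has no number, only a limit: the limit of > 10000 nM in this assay, at which 1 of the 3 values shown sits. Compound 4 is its close relative, with 4-methylphenyl in place of benzyl on a sulfonyl sulfur. Changes to the group on this oxygen have mattered: an at least 26-fold higher number from compound 2 to compound 3 (1.42 log units; beyond the scatter) and an at least 2.4-fold higher number from compound 1 to compound 3 (0.38 log units; beyond the scatter). Going by the values given here, both replaced the whole group, however, and no measured step changes only the group on the sulfonyl sulfur. A modest step towards a lower number is therefore expected, and compound 4 may still reach the limit. The expected step is an at least 1.4-fold lower number from compound 3 to compound 4 (0.15 log units; that floor lies within the scatter). The estimate for compound 4 is 7000 nM, within an expected range of 2000 nM to 20000 nM.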

Compound 4, half-maximal inhibitory concentration: 2400 nM
Estimate against measurement, compound 4: 2.9-fold (0.46 log units) above, within the range that was stated.
By their numbers in this assay, from the lowest: compound 2; then compounds 4 and 1 (each within the scatter of the next). At a limit, above all of these: compound 3.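

In this assay, going by these compounds alone, 4-methylphenyl in place of benzyl on a sulfonyl sulfur gives an at least 4.1-fold lower number from compound 3 to compound 4 (0.61 log units; beyond the scatter), the first step that changes only this group, so the group on the sulfur matters even though both have the same atoms. That size is only a floor, because compound 3 has a limit and not a number: the limit of > 10000 nM in this assay, at which 1 of the 4 values shown sits. Against the other groups on this oxygen, the sulfonyl group of compound 4 gives a 6.3-fold higher number from compound 2 to compound 4 (0.80 log units; beyond the scatter) and a 1.7-fold lower number from compound 1 to compound 4 (0.23 log units; within the scatter).

Still open, from the compounds shown here alone, is whether the methyl or the ring's direct attachment to sulfur carries the change, which phenyl on the sulfonyl sulfur would help separate.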